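Amide Aryl Variation in an Antiproliferative Series

A few compounds are considered here, and "the series" means these few. Any claim that something is new, unique, unknown or untested is made for them only; others in the source may bear on it.

Compound 3 `O=C(Nc1cccc(-c2oc3cc(-c4ccc(F)cc4)ccc3c(=O)c2O)c1)c1ccc(Br)cc1` gives 24900 nM in a functional assay on MDA-MB-231 cells (Homo sapiens) for antiproliferative activity, read by CCK-8 assay, with a stated time of 72 h (on this read-out lower numbers stand for stronger inhibition and higher numbers for weaker inhibition), the highest number among the three compounds measured. Compound 1 `O=C(Nc1cccc(-c2oc3cc(-c4ccc(F)cc4)ccc3c(=O)c2O)c1)c1ccc(F)cc1` gives 16000 nM in this assay, and compound 2 `COc1ccccc1C(=O)Nc1cccc(-c2oc3cc(-c4ccc(F)cc4)ccc3c(=O)c2O)c1` gives 5110 nM. Compound 4 `COc1ccc(C(=O)Nc2cccc(-c3oc4cc(-c5ccc(F)cc5)ccc4c(=O)c3O)c2)c(F)c1` differs from compound 3 by 2-fluoro-4-methoxyphenyl in place of 4-bromophenyl on a carbonyl carbon. Among the measured compounds shown here, the steps that bear on this change are a 1.6-fold higher number from compound 1 to compound 3 (0.19 log units; within the scatter), a 3.1-fold lower number from compound 1 to compound 2 (0.50 log units; beyond the scatter) and a 4.9-fold higher number from compound 2 to compound 3 (0.69 log units; beyond the scatter). A modest step to a lower number is expected in this assay, roughly a 3.1-fold lower number from compound 3 to compound 4 (0.49 log units; beyond the scatter), because the methoxy-bearing compound 2 gives 5110 nM while the halogen-bearing amides give the higher numbers. Compound 4 is therefore estimated at 8000 nM, with an expected range from 3000 nM to 25000 nM.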

Compound 4, half-maximal inhibitory concentration: 17600 nM
For compound 4 the middle estimate is 2.2-fold (0.34 log units) below the measured one, within the range that was stated.
By their numbers in this assay, from the lowest: compound 2; then compounds 1, 4 and 3 (each within the scatter of the next).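

In this assay the change to 2-fluoro-4-methoxyphenyl on the carbonyl carbon gives a 1.4-fold lower number from compound 3 to compound 4 (0.15 log units; within the scatter) and a 1.1-fold higher number from compound 1 to compound 4 (0.04 log units; within the scatter) so compound 4 stays level with both halogen-bearing amides. Against the other methoxy-bearing amide it gives a 3.4-fold higher number from compound 2 to compound 4 (0.54 log units; beyond the scatter) and so a methoxy group alone does not go with the lower number, with compound 4 the case against that pattern. No measurement shown gives a reason for this. Going by these compounds, what an amine or a carboxylic acid on this aryl ring would give remains open.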